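From Chloro to Iodo: What to Expect for Compound 4

The compounds below may be only part of what the source reports. "The series", "measured", "known", "first", "only" and "open" are said of these compounds alone.

Three compounds share one core and differ only in the group on one aromatic ring. Compound 1 `CC(C)c1cccc(NC(=O)N[C@@H](C)c2ccccc2)c1` carries isopropyl, compound 2 `CC(=O)c1cccc(NC(=O)N[C@@H](C)c2ccccc2)c1` carries acetyl, and compound 3 `C[C@H](NC(=O)Nc1cccc(Cl)c1)c1ccccc1` carries chloro. In an ADME assay on the whole organism with Oryza sativa as the target, tested at 10 uM (a higher number here means a weaker effect of the compound at the concentration tested, a lower number a stronger effect), compound 1 gives 86%, compound 2 gives 94% and compound 3 gives 103%. Compound 3 sits at the upper end of the three numbers: the step of a number 9 percentage points higher from compound 2 to compound 3 (within the scatter) is within the scatter, the step of a number 17 percentage points higher from compound 1 to compound 3 (beyond the scatter) is beyond it, and the step of a number 8 percentage points higher from compound 1 to compound 2 (within the scatter) is within it. Compound 4 `C[C@H](NC(=O)Nc1cccc(I)c1)c1ccccc1` is not yet measured; it differs from compound 3 by iodo in place of chloro on an aromatic carbon. Among the compounds with values here, no measured step exchanges one halogen for another, so the only guide is how modestly the whole set moves across three quite different groups at this place. Compound 4 is therefore expected to stay close to compound 3. The expected change is a number 3 percentage points lower from compound 3 to compound 4 (within the scatter), a step within the scatter. The estimate for compound 4 in this assay is 100%, with a range from 85% to 112%.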

Compound 4, a percentage reported as activity, at one concentration (the size of the read-out at that concentration, not a potency): 93%
For compound 4 the middle estimate is 7 percentage points above the measured one; low and high end bracket the measured number.
By their numbers in this assay, from the lowest: compounds 1, 4, 2 and 3 (each within the scatter of the next, the first and the last beyond it).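

In this assay, within the data shown here, the first exchange of one halogen for another at this place gives a number 10 percentage points lower from compound 3 to compound 4 (within the scatter) and so does not separate iodo from chloro. Iodo cannot be separated from the other two groups either, with a number 1 percentage points lower from compound 2 to compound 4 (within the scatter) and with a number 7 percentage points higher from compound 1 to compound 4 (within the scatter) as well, so the step from compound 1 to compound 3 stays the only one beyond the scatter, and all four groups on the aromatic carbon give numbers in one narrow band. Nothing available here explains these numbers.

Going by these compounds, whether an amine or a carboxylic acid in this place would move the number clearly away from that band remains open. Also open, on these data alone, is whether a change elsewhere on the shared core would matter more than any change at this position.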